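This account rests on a few compounds, and the source may have more. Where it says the series, first, only, none or still open, it means among the compounds named here.

Of the compounds shown here, three have so far been measured in an assay on membranes from CHO cells for displacement of a labelled ligand from adenosine receptor A1 (Homo sapiens), read by scintillation counting, with a stated time of 60 min, tested at 1 uM; on this read-out lower numbers stand for less inhibition and higher numbers for more inhibition at the one concentration tested (going by the name of the read-out). Compound 1 `CCCOC(=O)C1=C(C)NC(=O)NC1c1ccoc1` gives 50%, compound 2 `CCCOC(=O)C1=C(C)NC(=S)NC1c1ccco1` gives 1%, and compound 3 `CC1=C(C(=O)OC(C)C)[C@H](c2ccco2)NC(=S)N1` gives 10%. Compound 2 holds the lowest of the three numbers: compound 3 stands nearest, within the usual scatter, while compound 1 stands furthest, beyond it. Compound 4 `CC1=C(C(=O)OC(C)(C)C)C(c2ccco2)NC(=S)N1` has not yet been measured. It differs from compound 2 in one place: tert-butyl in place of propyl on an oxygen next to a carbonyl group. Within the data shown here, no step between measured compounds of this kind has been recorded, so the expectation rests on the values alone, and tert-butyl in place of propyl on an oxygen next to a carbonyl group is expected to give no step beyond the scatter in this assay. Compound 4 is therefore expected to give 8%, with a range from 0% to 25%. The step of a number 7 percentage points higher from compound 2 to compound 4 (within the scatter) is expected to be small.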

Compound 4, a percentage reported as inhibition, at one concentration (the size of the read-out at that concentration, not a potency): 3%
Compound 4: the middle estimate sits 5 percentage points above what was measured, and the stated range covers the measured number.
By their numbers in this assay, from the lowest: compounds 2, 4 and 3 (each within the scatter of the next); then compound 1.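

In this assay the position on the oxygen next to a carbonyl group now has its first recorded step, with tert-butyl in place of propyl giving a number 2 percentage points higher from compound 2 to compound 4 (within the scatter). On this core, the change from propoxy to tert-butoxy therefore leaves the read-out where it was, and both compounds remain low. Nothing available offers a reason for this result. From the compounds shown here alone, what stays open is whether a longer chain, or a chain ending in an amine or a carboxylic acid, would give a step beyond the scatter at this position. With compound 2 at 1%, any further fall from that number could hardly be seen.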